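Swapping a Formyl for an Ethynyl on a Ring Carbon

The source may hold more compounds than are shown below. What is called first, only, known or untested is meant among the compounds shown, and "the series" means these compounds.

Measured compounds:
Compound 1 `C=C1CC[C@@H](C(C)C)[C@]12CC=C(C=O)CC2` gives 550000 nM in an ADME assay on HEK293 cells (Homo sapiens) for cytotoxicity, read by MTT assay, with a stated time of 48 h; a lower number here means a stronger inhibitor, a higher number a weaker inhibitor.
Compound 2 `C=C1CCC[C@]2(C)CCC(C=O)=CC[C@@]12C` gives 734000 nM in this assay.

Both compounds share a two-ring carbon core and both are weak in this assay, with numbers far up the concentration scale. Compound 1 has the lower of the two numbers, but its gap to compound 2 is within the scatter of this kind of measurement, so neither can be called the stronger or the weaker of the pair.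

Compound 3 `C#CC1=CC[C@]2(CC1)C(=C)CC[C@H]2C(C)C` has not yet been measured. It differs from compound 1 by ethynyl in place of formyl on a double-bonded ring carbon. Among the measured compounds shown here, no step between two measured compounds covers this kind of change, so the expectation rests on the two numbers alone. Given that compound 1 shows only weak activity at 550000 nM and compound 2 sits close by at 734000 nM, the step of a 1.1-fold higher number from compound 1 to compound 3 (0.04 log units; within the scatter) is expected to stay within the scatter, with no clear direction. Compound 3 is therefore estimated at 600000 nM, with a range from 200000 nM to 2000000 nM.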

Compound 3, half-maximal inhibitory concentration: 741000 nM
Compound 3: middle estimate off by 1.2-fold (0.09 log units), on the low side, within the range that was stated.
By their numbers in this assay, from the lowest: compounds 1, 2 and 3 (each within the scatter of the next).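

In this assay the exchange of formyl for ethynyl on a double-bonded ring carbon gives a 1.3-fold higher number from compound 1 to compound 3 (0.13 log units; within the scatter) and so does not separate the two groups at this position, even though one hydrogen-bond acceptor and a double bond outside aromatic rings leave and a triple bond with no hydrogen-bond acceptor enters. Compound 1 and compound 2 differ in more than one place, so they could not show this; the new pair isolates a single change on this ring carbon, and here that change leaves the reading within the scatter. Nothing measured here explains why the two groups read alike, and no outside measurement bears on this result.

From the compounds shown here alone, every group tried at this ring carbon so far has just two heavy atoms and no hydrogen-bond donor, so it remains open whether an amine, a carboxylic acid or a longer chain there would move the number beyond the scatter. Going by these compounds, it is also open whether ethynyl in place of formyl would read the same way on the core of compound 2.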